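Two measured analogues and a bis-furan follow-up

The compounds below may be only part of what the source reports. "The series", "measured", "known", "first", "only" and "open" are said of these compounds alone.

Two compounds of a shared core have been examined in an assay on CHO cells for displacement of a labelled ligand from adenosine receptor A1 (Homo sapiens), read by scintillation counting, with a stated time of 3 h; on this read-out lower numbers stand for stronger inhibition and higher numbers for weaker inhibition. Compound 1 `Nc1nc(-c2ccco2)nc2sc(-c3ccccc3)nc12` gives 67 nM in this assay. Compound 2 `Nc1nc(-c2cccc(O)c2)nc2sc(-c3ccco3)nc12` gives 51 nM in this assay. Compound 2 carries the lowest of the two numbers, but its nearest neighbour, compound 1, lies within the usual scatter, so the two cannot be ranked against each other on these data.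

The next compound, compound 3 `Nc1nc(-c2ccco2)nc2sc(-c3ccco3)nc12`, is not yet measured in this assay. Against compound 2 it shows one change: furan-2-yl in place of 3-hydroxyphenyl on an aromatic carbon. Among the compounds with values here, no step of the same kind stands between measured compounds, so the direction of this change must be judged from the two values alone. Compound 1 shows that furan-2-yl at this place is compatible with a number close to that of compound 2, which suggests that compound 3 should stay in the same region.

Compound 3 is therefore expected to give 75 nM in this assay, in the range 25 nM to 220 nM. The expected step of a 1.5-fold higher number from compound 2 to compound 3 (0.17 log units; within the scatter) is estimated as small, at most a modest rise that need not exceed the scatter.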

Compound 3, inhibition constant: 69 nM
Compound 3: middle estimate off by 1.1-fold (0.04 log units), on the high side; the range from low to high includes it.
By their numbers in this assay, from the lowest: compounds 2, 1 and 3 (each within the scatter of the next).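

Within the data shown here, the step from a 3-hydroxyphenyl to a furan-2-yl on the aromatic carbon between two ring nitrogen atoms, a 1.4-fold higher number from compound 2 to compound 3 (0.13 log units; within the scatter) in this assay, gives the first direct reading at this place: the entering group has no hydrogen-bond donor and fewer heavy atoms, yet no change can be told from the scatter. The second step, a 1.0-fold higher number from compound 1 to compound 3 (0.01 log units; within the scatter), reads furan-2-yl in place of phenyl at the other ring-bearing aromatic carbon of the shared core, and it too shows no change that can be told from the scatter, so on these compounds neither place separates the two ring types it carries. No available data bear on why the numbers stay so close.

The compounds shown leave open whether this insensitivity holds only for aromatic rings or extends to quite different groups on the carbon between the two ring nitrogen atoms, such as an amine, a carboxylic acid or a longer alkyl chain. They also leave open whether a plain phenyl at that carbon, without the hydroxyl, would read the same as the 3-hydroxyphenyl of compound 2.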